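A few compounds are considered here, and "the series" means these few. Any claim that something is new, unique, unknown or untested is made for them only; others in the source may bear on it.

Measured so far:
compound 1, `Cc1ccccc1C(=O)n1c(-c2cn(-c3ccccc3)nc2-c2ccc(F)cc2)nc2ccccc21`, giving 189000 nM in an ADME assay on HEK-293T cells (Homo sapiens) for cytotoxicity, read by MTT assay, with a stated time of 24 h; a higher number here means that more compound is tolerated, a lower number that less compound is tolerated
compound 2, `Cc1ccc(C(=O)n2c(-c3cn(-c4ccccc4)nc3-c3ccc(C(F)(F)F)cc3)nc3ccccc32)cc1`, giving 169000 nM in this assay

Compound 1 holds the highest of the two numbers in this assay, but compound 2 sits so close to it that the two values lie within the scatter of each other, so no order between them can be read from these figures. Among the measured compounds shown here, no pair of measured compounds differs in one place, so no single step has been quantified yet.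

The next compound, compound 3, `Cc1cccc(C(=O)n2c(-c3cn(-c4ccccc4)nc3-c3ccc(F)cc3)nc3ccccc32)c1`, is not yet measured in this assay. It differs from compound 1 as follows: 3-methylphenyl in place of 2-methylphenyl on a carbonyl carbon. The same atoms are present in both, joined differently.

For the measured compounds named here, with only two measured compounds and no counted step to lean on, the expectation for compound 3 rests on compound 1 alone. The step of a 1.1-fold lower number from compound 1 to compound 3 (0.02 log units; within the scatter) is expected to be none beyond the scatter, because compound 1 gives 189000 nM and nothing measured points away from that. Compound 3 is therefore estimated at 180000 nM, with a range of 90000 nM to 360000 nM.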

Compound 3, half-maximal cytotoxic concentration: 148000 nM
For compound 3 the middle estimate is 1.2-fold (0.09 log units) above the measured one, within the range that was stated.
By their numbers in this assay, from the lowest: compounds 3, 2 and 1 (each within the scatter of the next).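

In this assay, among the compounds shown here, the change from 2-methylphenyl to 3-methylphenyl on a carbonyl carbon gives the first counted step (a 1.3-fold lower number from compound 1 to compound 3 (0.11 log units; within the scatter)). This step lies within the scatter, so the two methylphenyl groups cannot be told apart at this position, and no order between compound 1 and compound 3 can be read. No available evidence bears on this result.

The compounds shown leave open whether a group other than methyl on this phenyl ring, such as an amine or a carboxylic acid, would give a step beyond the scatter. They also leave open whether a longer chain in place of the methylphenyl group on the carbonyl carbon would do so.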